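Swapping Ethoxycarbonyl for Nitro on a Limit Compound

The source may hold more compounds than are shown below. What is called first, only, known or untested is meant among the compounds shown, and "the series" means these compounds.

In a functional assay on SK-OV-3 cells (Homo sapiens) for antiproliferative activity, read by MTT assay, with a stated time of 72 h (a lower number here means a stronger inhibitor, a higher number a weaker inhibitor), compound 1 `Cc1ccc(NC(=O)CCc2cccc3c2B(O)OC3)cc1` gives 860 nM. Going by these compounds, compound 2 `CCOC(=O)c1ccc(NC(=O)CCc2cccc3c2B(O)OC3)cc1` yields only a limit, > 100000 nM, so its true position is unknown. Compound 3 `O=C(CCc1cccc2c1B(O)OC2)Nc1ccc([N+](=O)[O-])cc1` keeps the shared core and differs from compound 2 by nitro in place of ethoxycarbonyl on an aromatic carbon, with nitro in place of ethoxycarbonyl on an aromatic carbon. Going by the values given here, one measured step bears on this place: an at least 110-fold higher number from compound 1 to compound 2 (2.06 log units; beyond the scatter). That large step leads to the expectation of a sizeable move toward a lower number, though with wide uncertainty. The expected change is an at least 10-fold lower number from compound 2 to compound 3 (1.00 log units; beyond the scatter). Compound 3 is estimated at 10000 nM, with a range of 1000 nM to 60000 nM.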

Compound 3, half-maximal inhibitory concentration: 83000 nM
Compound 3: the middle estimate sits 8.3-fold (0.92 log units) below what was measured; the measured number lies above the stated range.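

In this assay, the loss at this position is not confined to ethoxycarbonyl: nitro in place of methyl gives a 97-fold higher number from compound 1 to compound 3 (1.98 log units; beyond the scatter). Nitro in place of ethoxycarbonyl gives an at least 1.2-fold lower number from compound 2 to compound 3 (0.08 log units; that floor lies within the scatter), so no order between these two groups can be claimed. Compound 2 is recorded only as a limit, which leaves that comparison without an upper end: the limit of > 100000 nM in this assay, at which 1 of the 3 values shown sits.

Going by these compounds, whether an amine, a carboxylic acid or a longer alkyl chain on this aromatic carbon would keep the activity of compound 1 remains open.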